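The source may report more compounds than this note shows. Statements on the series, on what has been measured and on what is new or still open speak of the compounds shown alone.

Measured compounds:
Compound 1 `COc1cccc(C#Cc2sc3c(c2C(=O)N[C@@H](C)c2ccc(C(=O)O)cc2)CCOC3)c1` — 12.4 nM
Compound 2 `C[C@H](NC(=O)c1c(Cc2cc(F)c(Cl)cc2Cl)sc2c1CCOC2)c1ccc(C(=O)O)cc1` — 2.5 nM
Compound 3 `C[C@H](NC(=O)c1c(CCc2ccc(F)cc2)sc2c1CC(C)(C)OC2)c1ccc(C(=O)O)cc1` — 36.2 nM

All three were tested in a functional assay on CHO/Galpha16 cells for antagonist activity at prostaglandin E2 receptor EP4 subtype (Homo sapiens), read by calcium flux, with a stated time of 15 min; a lower number here means a stronger inhibitor, a higher number a weaker inhibitor. Among them compound 2 stands lowest, with compound 1 giving a number that is a 5.0-fold lower number from compound 1 to compound 2 (0.70 log units; beyond the scatter) away in the other direction, and compound 3 further still at 36.2 nM, where compound 2 gives 2.5 nM.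

Compound 4 `COc1cccc(Cc2sc3c(c2C(=O)N[C@@H](C)c2ccc(C(=O)O)cc2)CCOC3)c1` has not yet been measured. It differs from compound 2 in one place: 3-methoxyphenyl in place of 2,4-dichloro-5-fluorophenyl on a saturated chain carbon bound to an aromatic carbon. Among the measured compounds shown here, the only measured step that touches this change is the one from compound 1 to compound 2, which was a 5.0-fold lower number from compound 1 to compound 2 (0.70 log units; beyond the scatter); there compound 1 carried a 3-methoxyphenyl as well, though attached to the core in a different way, so the step is related but not the same. For the measured compounds named here, no measured pair reports the pure swap of the aryl group at a saturated chain carbon, and compound 3 carries a different core and a different chain.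

Taken together, the expectation is that compound 4 loses some potency against compound 2, by roughly a 5.6-fold higher number from compound 2 to compound 4 (0.75 log units; beyond the scatter), landing near compound 1. The estimate for compound 4 in this assay is 14 nM, within a range of 5 nM to 45 nM.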

Compound 4, half-maximal inhibitory concentration: 1.9 nM
Estimate against measurement, compound 4: 7.4-fold (0.87 log units) above; measured number below the stated range.
By their numbers in this assay, from the lowest: compounds 4 and 2 (each within the scatter of the next); then compound 1; then compound 3.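

In this assay, 3-methoxyphenyl in place of 2,4-dichloro-5-fluorophenyl on a saturated chain carbon bound to an aromatic carbon gives a 1.3-fold lower number from compound 2 to compound 4 (0.12 log units; within the scatter), so at this position the two aryl groups cannot be told apart and the halogens are not required for a low number. With the 3-methoxyphenyl kept, changing only the link to the core, 3-methoxybenzyl in place of 2-(3-methoxyphenyl)ethynyl, gives a 6.5-fold lower number from compound 1 to compound 4 (0.81 log units; beyond the scatter), which shows that the linker change alone can account for a step of the size of a 5.0-fold lower number from compound 1 to compound 2 (0.70 log units; beyond the scatter). No measurement at hand explains why these aryl groups read alike here.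

As far as these compounds go, whether an unsubstituted phenyl or an aryl group bearing an amine or a nitrile would also hold this level remains open. So does the effect of a longer chain on the shared core, since compound 3 differs in its core as well.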